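The source may report more compounds than this note shows. Statements on the series, on what has been measured and on what is new or still open speak of the compounds shown alone.

Measured compounds:
- compound 1 `CC(C)c1cccc(C(C)C)c1NC(=O)NS(=O)(=O)N(C)C` gives 3900 nM in an assay on liver for inhibition of sterol O-acyltransferase 1 (Rattus norvegicus), using microsomes; on this read-out lower numbers stand for stronger inhibition and higher numbers for weaker inhibition
- compound 2 `CC(C)(C)c1cccc(C(C)(C)C)c1OC(=O)NS(=O)(=O)NC(c1ccccc1)c1ccccc1` gives 11400 nM in this assay

Of the compounds shown here, two have been measured in this assay so far, and compound 2 holds the higher of the two numbers, meaning the weaker inhibition. Its nearest neighbour is compound 1, whose lower number sits at a distance beyond the usual scatter, so compound 2 is the weaker inhibitor of the pair. For the measured compounds named here, the two share a sulfonylurea-type linkage but differ in several places at once, so no single structural step between them can be read off.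

Compound 3 `Cc1cc(C(C)(C)C)c(OC(=O)NS(=O)(=O)NC(c2ccccc2)c2ccccc2)c(C(C)(C)C)c1` follows from compound 2 by one change: methyl in place of hydrogen on an aromatic carbon. Going by the values given here, no measured pair shows this change, so its effect is unknown. A single methyl on the aromatic ring, away from the acyl sulfamide chain, is expected to move the number little, and the expected step is a 1.3-fold lower number from compound 2 to compound 3 (0.10 log units; within the scatter), no further than the scatter in either direction. Compound 3 is therefore estimated to give 9000 nM in this assay, within a range from 3000 nM to 27000 nM.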

Compound 3, half-maximal inhibitory concentration: 11500 nM
Compound 3: the middle estimate sits 1.3-fold (0.11 log units) below what was measured; measured number inside the range.
By their numbers in this assay, from the lowest: compound 1; then compounds 2 and 3 (each within the scatter of the next).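

In this assay, for the compounds shown here, the exchange of hydrogen for methyl on the aromatic carbon that is meta to two tert-butyl groups and para to a large group gives a 1.0-fold higher number from compound 2 to compound 3 (0.00 log units; within the scatter) and is the first step here that can be read at a single place, as compound 1 and compound 2 differ in several places at once. At this position the added methyl leaves the read-out within the scatter, so one extra carbon here brings no change that can be told apart from repeat measurement. No measured property of the methyl group is at hand to account for this outcome.

From the compounds shown here alone, whether a larger or different group at the same aromatic carbon, such as an ethyl, a methoxy group or an amine, would also leave the number in place stays open, since a single methyl speaks only for itself. Also open, going by these compounds, is which of the several differences between compound 1 and compound 2 sets the gap between their numbers.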